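A few compounds are considered here, and "the series" means these few. Any claim that something is new, unique, unknown or untested is made for them only; others in the source may bear on it.

Compound 1, with the structure `CNC(=O)N1CC1C#N`, is one of three small urea-type molecules built on the same core and measured in a functional assay on OVCAR-3 cells (Homo sapiens) for inhibition; on this read-out lower numbers stand for stronger inhibition and higher numbers for weaker inhibition. In this assay compound 1 gives 14000 nM, which places it second highest among the three numbers. Its nearest neighbour is compound 2, `N#CC1CN1C(=O)NC1CCCCC1`, which in this assay gives 31000 nM; that gap lies beyond the usual scatter, so compound 2 is the weaker inhibitor of the two. Furthest from compound 1 is compound 3, `N#CC1CN1C(=O)Nc1ccc(F)cc1`, which in this assay gives 5900 nM, again a gap beyond the scatter, so compound 3 stands as the strongest of the three.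

Compound 4, `N#CC1CN1C(N)=O`, has not yet been measured. It differs from compound 1 in one place: hydrogen in place of methyl on an amide-type nitrogen. Within the data shown here, no pair among the measured compounds shows this kind of change, so there is no measured step to lean on. The measured numbers show that the group on that nitrogen matters, with compound 3 well below and compound 2 well above compound 1. Removing the group altogether is expected to give a modest weakening, roughly the size of the step from compound 1 to compound 2, so the estimated step of a 1.6-fold higher number from compound 1 to compound 4 (0.20 log units; within the scatter) points toward a higher number. Compound 4 is therefore estimated at 22000 nM, with a range from 8000 nM to 60000 nM.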

Compound 4, half-maximal inhibitory concentration: > 90000 nM
Compound 4 gave a limit, no number (the forecaster's own chance of this, stated with the estimate: 15%); middle value at least 4.0-fold (0.61 log units) away from the limit.
By their numbers in this assay, from the lowest: compound 3; then compound 1; then compound 2. At a limit, above all of these: compound 4.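

Replacing the methyl with hydrogen on the amide-type nitrogen gives an at least 6.4-fold higher number from compound 1 to compound 4 (0.80 log units; beyond the scatter), so this one small change, methylamino to amino, moves the result well beyond the usual scatter. Among these compounds, this is the first view of this nitrogen with no carbon group on it, and it shows that the single methyl of compound 1 matters a great deal in this assay, even though it is only one heavy atom. In this assay compound 4 gives > 90000 nM, which is a limit of the assay and not a number, so the step has a minimum size but no known full size: the limit of > 90000 nM in this assay, at which 1 of the 4 values shown sits.

The compounds shown leave open how the result changes as a carbon group on this nitrogen grows step by step from methyl, for example to an ethyl group or a longer straight chain. They also leave open whether a chain on this nitrogen ending in an amine or a carboxylic acid would keep the inhibition seen with compound 1 or lose it as compound 4 does.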